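The compounds below may be only part of what the source reports. "The series", "measured", "known", "first", "only" and "open" are said of these compounds alone.

Measured so far in a functional assay on HEL cells (Homo sapiens); on this read-out lower numbers stand for higher toxicity in this test and higher numbers for lower toxicity in this test:

Compound 1, `O=C1c2ccccc2N(Cc2ccccc2)S(=O)(=O)N1Cc1ccccc1`. In this assay compound 1 gives > 50000 nM, which is a limit of the assay and not a number.
Compound 2, `O=C1c2ccccc2N(Cc2ccccc2Cl)S(=O)(=O)N1COCc1ccccc1`. In this assay compound 2 gives 200000 nM.
Compound 3, `C#CCOCN1c2ccccc2C(=O)N(Cc2ccccc2)S1(=O)=O`. In this assay compound 3 gives 140000 nM.

Compound 3 therefore holds the lowest of the two numbers, but compound 2 sits within the usual scatter of it, so the two cannot be told apart. Compound 1 cannot be placed against either, since it is only known as the limit of > 50000 nM in this assay, at which 1 of the 3 values shown sits.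

Compound 4, `O=C1c2ccccc2N(Cc2ccccc2Cl)S(=O)(=O)N1Cc1ccccc1`, has not yet been measured. It differs from compound 3 in one place: 2-chlorophenyl in place of propargyloxy on a saturated chain carbon bound to a sulfonamide nitrogen in a ring. Going by the values given here, the only measured step at this position is a step that the limit leaves unreadable from compound 1 to compound 3, whose size stays hidden behind (the limit of > 50000 nM in this assay, at which 1 of the 3 values shown sits), so it gives no guidance on direction or size. Compound 2 also carries a 2-chlorophenyl group and is no more toxic than compound 3, which hints that the groups exchanged here leave toxicity roughly where it is.

Compound 4 is thus estimated at 150000 nM, with a likely range from 60000 nM to 350000 nM. The expected step of a 1.1-fold higher number from compound 3 to compound 4 (0.03 log units; within the scatter) would stay within the scatter.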

Compound 4, minimum cytotoxic concentration: 200000 nM
Compound 4: the middle estimate sits 1.3-fold (0.12 log units) below what was measured, within the range that was stated.
By their numbers in this assay, from the lowest: compounds 3, 2 and 4 (each within the scatter of the next).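

In this assay, going by these compounds alone, exchanging (propargyloxy)methyl for 2-chlorobenzyl on the sulfonamide nitrogen in a ring gives a 1.4-fold higher number from compound 3 to compound 4 (0.15 log units; within the scatter), the first step at this position that can be read, and it does not separate the two compounds. On the amide-type nitrogen in a ring, the exchange of benzyloxy for phenyl on the saturated chain carbon gives no change at the digits printed from compound 2 to compound 4 (within the scatter), so this second readable step also leaves the two compounds indistinguishable, and compounds 2, 3 and 4 cannot be ranked against one another in this assay. The steps from compound 1 cannot be read, since the value of compound 1 is a limit of the assay: the limit of > 50000 nM in this assay, at which 1 of the 4 values shown sits.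

Within the data shown here, what a chloro group alone does on the aromatic carbon therefore remains open, as its only step starts from that limit. It also remains open whether an amine, a carboxylic acid or a longer chain on the saturated chain carbon would move the number in this assay beyond the usual scatter, as the groups shown here do not.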